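The compounds below may be only part of what the source reports. "The series", "measured", "known", "first", "only" and "open" are said of these compounds alone.

Series notes: three measured analogues and one still open. Compound 1 `Cc1ccc(C2=NN(C3=NC(=O)CS3)C(c3ccc4ccccc4c3)C2)cc1` and compound 2 `Cc1ccc(C2=NN(C3=NC(c4ccccc4)CS3)C(c3cccc4ccccc34)C2)cc1` differ in more than one place; the difference between the two cores is not broken down here. Compound 3 `O=C1CSC(N2N=C(c3ccc(Cl)cc3)CC2c2ccc3ccccc3c2)=N1` carries the core of compound 1 with chloro in place of methyl on an aromatic carbon.

In a functional assay on BGC-823 cells (Homo sapiens) for inhibition, read by CCK-8 assay, with a stated time of 48 h (a lower number here means a stronger inhibitor, a higher number a weaker inhibitor), compound 1 gives 7790 nM. In this assay compound 3 gives 13200 nM, so that a 1.7-fold higher number from compound 1 to compound 3 (0.23 log units; within the scatter). In this assay compound 2 gives 13300 nM; its number and that of compound 3 sit within the scatter of one another, and the same holds for its number against compound 1, so no ranking among the three is supported.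

Compound 4 `Clc1ccc(C2=NN(C3=NC(c4ccccc4)CS3)C(c3cccc4ccccc34)C2)cc1` is the still unmeasured analogue. It relates to compound 2 as compound 3 relates to compound 1: chloro in place of methyl on an aromatic carbon, at a place described in the same words for both pairs, so this is the same change rather than merely the same kind. The corresponding step is expected to be a 1.4-fold higher number from compound 2 to compound 4 (0.13 log units; within the scatter) because a 1.7-fold higher number from compound 1 to compound 3 (0.23 log units; within the scatter) measured this very exchange on the neighbouring core and stayed within the scatter. On that basis compound 4 is expected to give about 18000 nM in this assay, estimated to fall between 8000 nM and 40000 nM.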

Compound 4, half-maximal inhibitory concentration: 19600 nM
For compound 4 the middle estimate is 1.1-fold (0.04 log units) below the measured one; the range from low to high includes it.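

In this assay, the exchange of 4-methylphenyl to 4-chlorophenyl on the core of compound 2 gives a 1.5-fold higher number from compound 2 to compound 4 (0.17 log units; within the scatter). Set beside the earlier step, the same exchange reads alike on the two cores, with no difference between them beyond the scatter: the same change on two cores in this assay, a 1.7-fold higher number (0.23 log units; within the scatter) from compound 1 to compound 3 and a 1.5-fold higher number (0.17 log units; within the scatter) from compound 2 to compound 4, 1.1-fold (0.06 log units) apart, within the scatter of two such steps. This shows that, for these two pairs, the exchange carries from one core to the other without a detectable shift in the step, but neither step separates chloro from methyl in this assay, and two cores say nothing about how the exchange would read on a third.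

The compounds shown leave open whether any other group at this place, para to a large group, such as methoxy, nitrile, an amine or a carboxylic acid, or a longer chain in place of methyl, would give a step beyond the scatter. The two cores also differ from each other in more than one place, and no pair among these four compounds isolates any one of those differences, so what each contributes in this assay remains unresolved.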